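A few compounds are considered here, and "the series" means these few. Any claim that something is new, unique, unknown or untested is made for them only; others in the source may bear on it.

Measured so far in a physicochemical assay for solubility, at pH 7.4; a higher number here means a more soluble compound, a lower number a less soluble compound:
- compound 1 `COc1ccc(C2OC(c3cc(OC)c(OC)c(OC)c3)=NN2C(C)=O)cc1OC(C)=O`: 112000 nM
- compound 2 `COc1cc(C2=NN(C(C)=O)C(c3cccc(Br)c3)O2)cc(OC)c1OC`: 66000 nM
- compound 3 `COc1ccc(C2=NN(C(C)=O)C(c3cc(OC)c(OC)c(OC)c3)O2)cc1`: 257000 nM

Compound 3 holds the highest of the three numbers, and its gaps down to compound 1 and to compound 2 both lie beyond the usual scatter. Next to consider is compound 4 `COc1ccc(C2=NN(C(C)=O)C(c3cc(OC)cc(OC)c3)O2)cc1`, not yet measured. It differs from compound 3 by hydrogen in place of methoxy on an aromatic carbon, ortho to two methoxy groups and para to a large group: hydrogen in place of methoxy on an aromatic carbon.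

Going by the values given here, no two measured compounds differ in one place only, so the series offers no direct precedent for this change, and any expectation is loose. Among the compounds with values here, a moderate step to a lower number in this assay is expected, perhaps not far beyond the scatter, with no step at all still possible. The main ground is position: compound 3 at 257000 nM already stands at the top of the set, so a fall looks more likely than a rise. The expected step is a 1.8-fold lower number from compound 3 to compound 4 (0.26 log units; within the scatter). For compound 4 the estimated value is 140000 nM, with an expected range from 50000 nM to 320000 nM.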

Compound 4, solubility: 94000 nM
Estimate against measurement, compound 4: 1.5-fold (0.17 log units) above, within the range that was stated.
By their numbers in this assay, from the lowest: compounds 2, 4 and 1 (each within the scatter of the next); then compound 3.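

In this assay the series now has its first pair of compounds differing in one place: hydrogen in place of methoxy on an aromatic carbon, ortho to two methoxy groups and para to a large group, gives a 2.7-fold lower number from compound 3 to compound 4 (0.44 log units; beyond the scatter) and thereby ties a measured change to this single position. The step is modest but lies beyond the scatter, so in this series the read-out is not indifferent to this methoxy, whose removal takes away two heavy atoms and one hydrogen-bond acceptor while leaving the other two methoxy groups on that ring in place. No measurement shown here explains the step, so it stands as an observation without an established cause.

Going by these compounds, this position has so far been read with only methoxy and hydrogen, so it remains open where a hydroxy group, a fluorine atom, an amine, a carboxylic acid or a longer chain such as ethoxy would fall relative to these two. One pair also leaves open whether the same replacement would give a step of similar size and direction with a different group on the other aromatic ring of the shared core.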